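Fluoro Substitution and Cytotoxicity in a Small Amide Series

The source may report more compounds than this note shows. Statements on the series, on what has been measured and on what is new or still open speak of the compounds shown alone.

Three compounds have been examined in an ADME assay on HEK-293T cells (Homo sapiens) for cytotoxicity, read by MTT assay, with a stated time of 72 h; on this read-out higher numbers stand for weaker inhibition and lower numbers for stronger inhibition. For the measured compounds named here, compound 1 `Cc1ccc2nc(NC(=O)c3cn(-c4ccccc4)nc3-c3ccccc3)sc2c1` is the first of them. In this assay compound 1 gives > 50000 nM, which is a limit of the assay and not a number. Compound 2 `Cc1ccc2nc(NC(=O)c3cn(-c4ccccc4)nc3-c3ccc(F)cc3)sc2c1` carries one change relative to compound 1: fluoro in place of hydrogen on an aromatic carbon. In this assay compound 2 also gives a limit, > 50000 nM. The step that the two limits leave unreadable from compound 1 to compound 2 therefore cannot be sized, consistent with the limit of > 50000 nM in this assay, at which 2 of the 3 values shown sit.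

Compound 3 `COc1ccc(-c2nn(-c3ccccc3)cc2C(=O)Nc2nc3ccccc3s2)cc1` has a different core from compound 1; how the two cores differ is not broken down here. In this assay, going by the values given here, compound 3 gives 18900 nM, the only number among the three values.

Compound 4 `COc1ccc(-c2nn(-c3ccccc3)cc2C(=O)Nc2nc3ccc(F)cc3s2)cc1` has not yet been measured. It differs from compound 3 by fluoro in place of hydrogen on an aromatic carbon. This is the same kind of change as from compound 1 to compound 2, but not the same: there the place is para to a large group, here it is part of a fused or bridged system of two rings, meta to a fused ring and para to a fused ring.

The step from compound 3 to compound 4 is expected to be a 1.3-fold higher number from compound 3 to compound 4 (0.12 log units; within the scatter). Compound 4 is expected to give about 25000 nM, with a plausible span from 8000 nM to 80000 nM. This expectation rests on the value of compound 3, 18900 nM. It also takes into account the step that the two limits leave unreadable from compound 1 to compound 2.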

Compound 4, half-maximal inhibitory concentration: 15400 nM
For compound 4 the middle estimate is 1.6-fold (0.21 log units) above the measured one; the range from low to high includes it.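

In this assay, the fluoro change on the core of compound 3, read as 1,3-benzothiazol-2-yl to 6-fluoro-1,3-benzothiazol-2-yl, gives a 1.2-fold lower number from compound 3 to compound 4 (0.09 log units; within the scatter), so on this core the two values cannot be told apart. The matching step on the core of compound 1 cannot be read, as the values of compound 1 and compound 2 are each a limit of the assay and not a number: the limit of > 50000 nM in this assay, at which 2 of the 4 values shown sit. For the compounds shown here, the change can therefore be sized on one core only, and in a different place from the one it takes in compound 2, so this series shows neither that its result carries from one core to another nor that it fails to carry.

The compounds shown leave open whether an amine or a carboxylic acid in place of the fluoro of compound 4, or a longer chain there, would give a step beyond the scatter. They also leave open what fluoro in place of hydrogen does on a second core where both values of the pair are numbers rather than limits, and so whether the result for compound 4 holds anywhere else in the series.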